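The compounds below may be only part of what the source reports. "The series", "measured", "known", "first", "only" and "open" are said of these compounds alone.

In a functional assay on A549 cells (Homo sapiens) for cytotoxicity, read by sulforhodamine B assay, with a stated time of 48 h (a lower number here means a stronger inhibitor, a higher number a weaker inhibitor), compound 3, `COc1ccc(/C=C/C(=O)c2cccc(Br)c2)cc1`, gives 34200 nM, which places it among the weak inhibitors of this small set. Compound 1, `O=C(/C=C/c1ccc(Br)cc1)c1cccc(-c2cccc(F)c2)c1`, gives 19800 nM, and the gap between these two lies within the usual scatter of repeated measurements. Compound 2, `COc1ccc(/C=C/C(=O)c2cccc(-c3cccc(F)c3)c2)cc1O`, gives 500 nM, a far lower number than either of them.

The next compound, compound 4, `COc1ccc(/C=C/C(=O)c2cccc(-c3cccc(F)c3)c2)cc1`, is made on paper by one swap on compound 3: 3-fluorophenyl in place of bromo on an aromatic carbon, (3-fluorophenyl in place of bromo on an aromatic carbon). Among the measured compounds shown here, no measured pair isolates this swap, so the evidence is indirect. The 3-fluorophenyl group also appears in compound 1 at 19800 nM and in compound 2 at 500 nM, so carrying it does not fix the value in this assay. A moderate move to a lower number, beyond the scatter, is expected. The estimated step is a 6.8-fold lower number from compound 3 to compound 4 (0.84 log units; beyond the scatter). For compound 4 the estimated value is 5000 nM, with an expected range of 1200 nM to 20000 nM.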

Compound 4, half-maximal inhibitory concentration: 2440 nM
The estimate for compound 4 lay 2.0-fold (0.31 log units) above the measured number; low and high end bracket the measured number.
By their numbers in this assay, from the lowest: compound 2; then compound 4; then compounds 1 and 3 (each within the scatter of the next).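

In this assay, the swap at this aromatic carbon now has a directly measured pair: 3-fluorophenyl in place of bromo gives a large move to a lower number (a 14-fold lower number from compound 3 to compound 4 (1.15 log units; beyond the scatter)). With 3-fluorophenyl held in place, changes elsewhere still shift the result: hydrogen in place of hydroxy raises the number (a 4.9-fold higher number from compound 2 to compound 4 (0.69 log units; beyond the scatter)), while methoxy in place of bromo lowers it (an 8.1-fold lower number from compound 1 to compound 4 (0.91 log units; beyond the scatter)). Nothing available here explains why any of these steps occurs.

The compounds shown do not tell whether the lower number with 3-fluorophenyl depends on the fluorine or on the added ring alone, a question that a plain phenyl group at this carbon would address. On these data alone, how an amine or a carboxylic acid at the same carbon would compare also remains open.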